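The compounds below may be only part of what the source reports. "The series", "measured", "known", "first", "only" and "open" are said of these compounds alone.

Measured compounds:
- compound 1, `O=C(CCCCCCCc1ccccc1)c1nnc(-c2ccccn2)o1`, in an assay on isolated protein for inhibition of liver carboxylesterase 1 (Homo sapiens), read by radioligand binding (a lower number here means a stronger inhibitor, a higher number a weaker inhibitor), gives 200 nM
- compound 2, `O=C(CCCCCc1ccccc1)C(F)(F)F`, gives 0.5 nM
- compound 3, `O=C(CCCCCCCc1ccccc1)C(F)(F)F`, gives 5 nM

Compound 1 stands at the highest of these three numbers, so it is the weakest inhibitor of the set; both compound 2 and compound 3 sit well beyond the usual scatter from it. Compound 2 and compound 3 share a trifluoromethyl ketone and differ only in the length of the chain carrying the phenyl ring; what their two values show is that the shorter chain goes with the lower number.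

Compound 4, `O=C(CCCCCc1ccccc1)c1nnc(-c2ccccn2)o1`, has not yet been measured. It differs from compound 1 in one place: phenyl in place of phenethyl on a saturated chain carbon, five bonds along the chain from a carbonyl carbon. This is the same shortening of the chain seen between compound 3 and compound 2, now applied to the core of compound 1. For the measured compounds named here, whether that holds for this core is unknown, since no such step has been measured here. The step from compound 1 to compound 4 in this assay is expected to be a 3.3-fold lower number from compound 1 to compound 4 (0.52 log units; beyond the scatter), a decrease beyond the scatter. Compound 4 is therefore estimated at 60 nM, within a range of 15 nM to 300 nM.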

Compound 4, half-maximal inhibitory concentration: 30 nM
For compound 4 the middle estimate is 2.0-fold (0.30 log units) above the measured one; the measured number falls inside the stated range.
By their numbers in this assay, from the lowest: compound 2; then compound 3; then compound 4; then compound 1.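

In this assay, phenyl in place of phenethyl on a saturated chain carbon, five bonds along the chain from a carbonyl carbon, gives a 6.7-fold lower number from compound 1 to compound 4 (0.82 log units; beyond the scatter), so shortening the chain also lowers the number on the core of compound 1. The trifluoromethyl ketones run the same way, with compound 3 at 5 nM and compound 2 at 0.5 nM, so among these two pairs the shorter chain goes with the lower number. Nothing available here explains why the shorter chain gives the lower number.

For the compounds shown here, still open is whether a shorter chain than the one in compound 4 would lower the number further on this core. On these data alone, it is also open how a carboxylic acid or an amine in place of phenyl would change the number.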